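Buffer Stability of Carbamate Variants on a Shared Core

The source may report more compounds than this note shows. Statements on the series, on what has been measured and on what is new or still open speak of the compounds shown alone.

Compound 2 `CC(OC(=O)C(C)C)OC(=O)N1CCN(C(=O)c2nc(Nc3cc(C4CC4)[nH]n3)c3cc(Cl)ccc3n2)C[C@H]1C` is one of three carbamates on a shared core examined in a physicochemical assay, read by HPLC, in phosphate buffer, with a stated time of 2 h, at pH 7.4; a higher number here means that more of the compound is left, a lower number that less of the compound is left. In this assay compound 2 gives 96.6%, and it sits within the scatter of compound 1 `CCOC(=O)N1CCN(C(=O)c2nc(Nc3cc(C4CC4)[nH]n3)c3cc(Cl)ccc3n2)C[C@H]1C`, which gives 97.7%, and of compound 3 `C[C@@H]1CN(C(=O)c2nc(Nc3cc(C4CC4)[nH]n3)c3cc(Cl)ccc3n2)CCN1C(=O)OCc1ccccc1`, which gives 97.7%. Compound 4 `C[C@@H]1CN(C(=O)c2nc(Nc3cc(C4CC4)[nH]n3)c3cc(Cl)ccc3n2)CCN1C(=O)OCC(Cl)(Cl)Cl` differs from compound 2 by 2,2,2-trichloroethyl in place of 1-((isopropylcarbonyl)oxy)ethyl on an oxygen next to a carbonyl group. The measured steps that bear on it all change the group on the same oxygen next to a carbonyl group: a number 1.1 percentage points lower from compound 1 to compound 2 (within the scatter), no change at the digits printed from compound 1 to compound 3 (within the scatter) and a number 1.1 percentage points higher from compound 2 to compound 3 (within the scatter). None of them moved this assay beyond the scatter, so no step beyond it is expected here either. Compound 4 is therefore expected to give 97%, between 92% and 100%. That estimate means a step of a number 0.4 percentage points higher from compound 2 to compound 4 (within the scatter).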

Compound 4, percent of the compound remaining: 98.7%
Estimate against measurement, compound 4: 1.7 percentage points below; the measured number falls inside the stated range.
By their numbers in this assay, from the lowest: compounds 2, 1, 3 and 4 (each within the scatter of the next).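

With 2,2,2-trichloroethyl on the oxygen next to a carbonyl group, this assay gives the steps of a number 2.1 percentage points higher from compound 2 to compound 4 (within the scatter), a number 1 percentage points higher from compound 3 to compound 4 (within the scatter) and a number 1 percentage points higher from compound 1 to compound 4 (within the scatter). This chlorine-bearing group therefore joins the ethyl, benzyl and 1-((isopropylcarbonyl)oxy)ethyl groups as a change at this position that stays within the scatter. Nothing available explains why these readings stay so close. The compounds shown leave open whether a chain ending in an amine or a carboxylic acid on this oxygen would also stay within the scatter.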